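Changing the Amino Side Chain of Compound 3

The source may hold more compounds than are shown below. What is called first, only, known or untested is meant among the compounds shown, and "the series" means these compounds.

compound 1 `CC[C@H](C)[C@H](NCC(=O)NNC(=O)COc1ccc(-c2nc3ccccc3s2)cc1OC)C(=O)O` gives 1710 nM
compound 2 `COc1cc(-c2nc3ccccc3s2)ccc1OCC(=O)NNC(=O)CN(C(C)=O)[C@@H](CS)C(=O)O` gives 1750 nM
compound 3 `CCOC(=O)CN(C)CC(=O)NNC(=O)COc1ccc(-c2nc3ccccc3s2)cc1OC` gives 1980 nM

These three values were all measured in a functional assay on MCF7 cells (Homo sapiens) for inhibition, read by MTT assay, with a stated time of 3 days (on this read-out lower numbers stand for stronger inhibition and higher numbers for weaker inhibition), and they lie close together. Compound 3 stands level with the other two within the scatter, as a 1.2-fold higher number from compound 1 to compound 3 (0.06 log units; within the scatter) and a 1.1-fold higher number from compound 2 to compound 3 (0.05 log units; within the scatter) show.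

The next compound is compound 4 `CCOC(=O)[C@H](NCC(=O)NNC(=O)COc1ccc(-c2nc3ccccc3s2)cc1OC)[C@@H](C)CC`, and the change leading to it is (1-(ethoxycarbonyl)-2-methylbutyl)amino in place of ((ethoxycarbonyl)methyl)(methyl)amino on a saturated chain carbon bound to a carbonyl carbon. In words, it places (1-(ethoxycarbonyl)-2-methylbutyl)amino in place of ((ethoxycarbonyl)methyl)(methyl)amino on a saturated chain carbon bound to a carbonyl carbon.

All three measured steps change the group on this same carbon, so all of them bear on the new step. Besides the two steps to compound 3, there is a 1.0-fold higher number from compound 1 to compound 2 (0.01 log units; within the scatter). None of them goes beyond the scatter, even though the groups exchanged differ considerably. Within the data shown here, no measured compound carries the entering group itself, so this evidence is indirect. A step beyond the scatter is therefore not expected, and no direction can be favoured. The expected change is a 1.1-fold lower number from compound 3 to compound 4 (0.04 log units; within the scatter).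

For compound 4 the estimated value is 1800 nM, with an expected range from 950 nM to 3400 nM.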

Compound 4, half-maximal inhibitory concentration: 2900 nM
Compound 4: middle estimate off by 1.6-fold (0.21 log units), on the low side; the range from low to high includes it.
By their numbers in this assay, from the lowest: compounds 1, 2, 3 and 4 (each within the scatter of the next).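

In this assay, the (1-(ethoxycarbonyl)-2-methylbutyl)amino group on a saturated chain carbon bound to a carbonyl carbon adds one more exchange that stays within the scatter, with a 1.5-fold higher number from compound 3 to compound 4 (0.17 log units; within the scatter) in the direct step and a 1.7-fold higher number from compound 2 to compound 4 (0.22 log units; within the scatter) against the side chain carrying the acetyl and sulfanyl groups. The pair not seen before is the one that differs only at the end of the same side chain on an amine nitrogen, where 1-(ethoxycarbonyl)-2-methylbutyl takes the place of 1-carboxy-2-methylbutyl and the result is a 1.7-fold higher number from compound 1 to compound 4 (0.23 log units; within the scatter) so that, within this read-out, the ethoxycarbonyl and carboxy forms of this side chain cannot be told apart. No accompanying measurement accounts for the size or the direction of these steps.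

All four side chains shown contain an ester or a carboxylic acid, so it remains open whether a side chain ending in a primary amine or an amide would also stay within the scatter. On these data alone, it is equally open whether a longer chain on the amine nitrogen, or a ring in place of the 2-methylbutyl part, would do so.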